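This account rests on a few compounds, and the source may have more. Where it says the series, first, only, none or still open, it means among the compounds named here.

Measured compounds in a physicochemical assay for solubility, read by LC-MS, in phosphate buffer, with a stated time of 24 h, at pH 7.4; on this read-out lower numbers stand for lower solubility and higher numbers for higher solubility:
- compound 1 `CNC(=O)c1cc(-c2cnc(NCc3c(F)ccc4c3CCO4)c3cn[nH]c(=O)c23)n(C)n1` gives 7000 nM
- compound 2 `O=C(Nc1ccccc1)c1cnc(NCc2c(F)ccc3c2CCO3)n2cnnc12` gives < 1000 nM, which is a limit of the assay and not a number
- compound 3 `CNC(=O)c1ncc(-c2cnc(NCc3c(F)ccc4c3CCO4)c3cn[nH]c(=O)c23)n1C` gives 5000 nM

Compound 2 stands at the lower edge of the numbers shown: its value in this assay is reported only as a limit, (the limit of < 1000 nM in this assay, at which 1 of the 3 values shown sits), so nothing more than that boundary is known for it, while compound 1 and compound 3 both sit above that boundary with numbers of their own.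

For the measured compounds named here, the one measured step, a 1.4-fold lower number from compound 1 to compound 3 (0.15 log units; within the scatter), concerns a change on a different part of a different core and does not bear on the present change.

Compound 4 `CN(C(=O)c1ccccc1)c1cnc(NCc2c(F)ccc3c2CCO3)n2cnnc12` differs from compound 2 by benzoyl(methyl)amino in place of phenylcarbamoyl on an aromatic carbon. Going by the values given here, no measured step covers this kind of change, so no direction can be read from the data for this assay; the expectation rests on the limit of compound 2 alone, with the number kept near that boundary and the range left wide.

Compound 4 is expected to give about 1500 nM in this assay, within a range of 500 nM to 6000 nM. The step this estimate implies, an at least 1.5-fold higher number from compound 2 to compound 4 (0.17 log units; that floor lies within the scatter), is an expectation only, not a measured difference.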

Compound 4, solubility: 280000 nM
Compound 4: the middle estimate sits 190-fold (2.27 log units) below what was measured; measured number above the stated range.
By their numbers in this assay, from the lowest: compounds 3 and 1 (each within the scatter of the next); then compound 4. At a limit, below all of these: compound 2.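

In this assay, this position on the shared core is far from indifferent to the group it carries, with benzoyl(methyl)amino in place of phenylcarbamoyl giving a large step: an at least 280-fold higher number from compound 2 to compound 4 (2.44 log units; beyond the scatter). For the compounds shown here, the two groups have the same six-membered aromatic ring of carbon only and the same hydrogen-bond acceptor count, and differ by 0 hydrogen-bond donors against 1 hydrogen-bond donor and by one heavy atom, so a small counted change goes with a large change in the read-out; the only earlier step lay elsewhere, on a different core, and gave no view of this. Compound 2 has only a limit of the assay rather than a number, so the true size of the step stays unknown and only its floor is fixed: the limit of < 1000 nM in this assay, at which 1 of the 4 values shown sits.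

Still open, as far as these compounds go, is which part of the exchange goes with the step, the methyl on the amide nitrogen or the reversed direction of the amide; a benzoylamino group or a methyl(phenyl)carbamoyl group on this carbon would separate the two. Also open, from the compounds shown here alone, is how an amine or a carboxylic acid would read at this position.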